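Adding chloro to the aryl ring of compound 2

The source may report more compounds than this note shows. Statements on the series, on what has been measured and on what is new or still open speak of the compounds shown alone.

Within the data shown here, in an assay on membranes from brain for binding affinity to Lysophosphatidylserine lipase ABHD12 (Mus musculus), read by fluorescence, with a stated time of 20 min (on this read-out higher numbers stand for weaker inhibition and lower numbers for stronger inhibition), compound 2 `FC(F)(F)c1ccnc(N2CCC(NC(=S)Nc3cccnc3)CC2)c1` gives 640 nM, the only number obtained so far. Compound 1 `S=C(Nc1cccnc1)NC1CCN(c2ncccc2Cl)CC1` returns only a limit, > 5000 nM. Among the measured compounds shown here, compound 2 therefore stands as the single measured value next to the limit of > 5000 nM in this assay, at which 1 of the 2 values shown sits. Compound 3 `FC(F)(F)c1ccnc(N2CCC(NC(=S)Nc3cccnc3)CC2)c1Cl` differs from compound 2 by chloro in place of hydrogen on an aromatic carbon. For the measured compounds named here, no measured step of this kind exists, so no size is known for it; in this assay the step is expected to remain within or near the scatter, if anything slightly weaker. For compound 3 the estimate is 900 nM (range 250 nM to 3500 nM), a step of a 1.4-fold higher number from compound 2 to compound 3 (0.15 log units; within the scatter) that is expected to be small.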

Compound 3, half-maximal inhibitory concentration: 300 nM
The estimate for compound 3 lay 3.0-fold (0.48 log units) above the measured number, and the stated range covers the measured number.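

Chloro in place of hydrogen on the aromatic carbon ortho to a trifluoromethyl group, read in this assay, gives a 2.1-fold lower number from compound 2 to compound 3 (0.33 log units; beyond the scatter), so this position accepts a substituent. With chloro in place, adding the trifluoromethyl group gives an at least 16-fold lower number from compound 1 to compound 3 (1.22 log units; beyond the scatter), so chloro without the trifluoromethyl group does not keep the activity of compound 3. That step has only a lower bound, as compound 1 is a limit and not a number: the limit of > 5000 nM in this assay, at which 1 of the 3 values shown sits.

Open, going by these compounds, is whether the gain is specific to chloro or also extends to a methyl group, a methoxy group or an amine at this position.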